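The source may hold more compounds than are shown below. What is called first, only, known or untested is meant among the compounds shown, and "the series" means these compounds.

Series so far, in a functional assay on MCF7 cells (Homo sapiens) for inhibition, with a stated time of 48 h; on this read-out higher numbers stand for weaker inhibition of growth and lower numbers for stronger inhibition of growth:

Compound 1 (`COc1c(C(=O)/C=C/c2ccc(Cl)cc2)c(O)c(Br)c2occc12`) : 2360 nM
Compound 2 (`C=CCc1c(O)c(C(=O)/C=C/c2ccccc2)c(OC)c2ccoc12`) : 2730 nM

Among the measured compounds shown here, compound 2 has only one neighbour on the scale so far: compound 1 at 2360 nM lies within the scatter of compound 2 at 2730 nM on this read-out.

Compound 3 (`C=CCc1c(O)c(C(=O)/C=C/c2ccc(Cl)cc2)c(OC)c2ccoc12`) keeps the core of compound 2 and goes from phenyl to 4-chlorophenyl, with chloro in place of hydrogen on an aromatic carbon. For the measured compounds named here, no measured pair isolates this change. Going by the values given here, the only hint is compound 1, which carries 4-chlorophenyl with other substituents on the core and gives 2360 nM, within the scatter of compound 2. In this assay no shift beyond the scatter is therefore expected, only a slight lean towards stronger inhibition of growth, and the estimated 1.4-fold lower number from compound 2 to compound 3 (0.14 log units; within the scatter) stays small. For compound 3 the estimate is 2000 nM, with 900 nM to 4500 nM as the expected range.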

Compound 3, concentration for 50% growth inhibition: 2510 nM
Compound 3: the middle estimate sits 1.3-fold (0.10 log units) below what was measured; low and high end bracket the measured number.
By their numbers in this assay, from the lowest: compounds 1, 3 and 2 (each within the scatter of the next).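

In this assay, among the compounds shown here, chloro in place of hydrogen on an aromatic carbon, para to a large group, gives a 1.1-fold lower number from compound 2 to compound 3 (0.04 log units; within the scatter) and stays within the scatter, so this pair isolates phenyl to 4-chlorophenyl for the first time and shows no measurable effect of that change here. With 4-chlorophenyl held constant, allyl in place of bromo on an aromatic carbon gives a 1.1-fold higher number from compound 1 to compound 3 (0.03 log units; within the scatter) and is also within the scatter, so neither change separates these compounds on this read-out. Nothing at hand bears on the reason for either result.

Going by these compounds, whether an amine or a carboxylic acid in place of chloro would shift the number remains open. So does the outcome for a longer chain in place of allyl.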